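The source may hold more compounds than are shown below. What is called first, only, known or untested is meant among the compounds shown, and "the series" means these compounds.

In a functional assay on NCI-H226 cells (Homo sapiens) for inhibition, read by sulforhodamine B assay, with a stated time of 48 h (on this read-out higher numbers stand for weaker inhibition of growth and lower numbers for stronger inhibition of growth), compound 1 `Cc1ccc(C2=NN(c3ccc(S(C)(=O)=O)cc3)C(=O)CC2)cc1` gives 430 nM. Compound 2 `Cc1cc(O)ccc1C1=NN(c2ccc(S(C)(=O)=O)cc2)C(=O)CC1` gives > 100000 nM, which is a limit of the assay and not a number, so its place on the scale is known only as that limit. Among the compounds with values here, the one measured step, an at least 230-fold higher number from compound 1 to compound 2 (2.36 log units; beyond the scatter), is large and beyond the scatter, and it came with 4-hydroxy-2-methylphenyl in place of 4-methylphenyl. Compound 3 `CCc1ccc(C2=NN(c3ccc(S(C)(=O)=O)cc3)C(=O)CC2)cc1` instead carries 4-ethylphenyl in place of 4-hydroxy-2-methylphenyl on a carbon with a double bond to nitrogen. Within the data shown here, this change removes the same 4-hydroxy-2-methylphenyl group, so the step to compound 1 is the only guide, and it suggests a large move in this assay towards a lower number. The expected step is an at least 160-fold lower number from compound 2 to compound 3 (2.22 log units; beyond the scatter). For compound 3 the estimated value is 600 nM, with an expected range of 150 nM to 3000 nM.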

Compound 3, concentration for 50% growth inhibition: 200 nM
Compound 3: middle estimate off by 3.0-fold (0.48 log units), on the high side; low and high end bracket the measured number.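

In this assay, the group on the carbon with a double bond to nitrogen now shows a gain as well as a loss: lengthening 4-methylphenyl to 4-ethylphenyl gives a 2.2-fold lower number from compound 1 to compound 3 (0.33 log units; beyond the scatter), a modest step but beyond the scatter. The change away from 4-hydroxy-2-methylphenyl gives an at least 500-fold lower number from compound 2 to compound 3 (2.69 log units; beyond the scatter), so a second compound with a simple alkyl-bearing ring lies far on the stronger side of compound 2. That step has only a bound for its size, as compound 2 stands at a limit and not at a number: the limit of > 100000 nM in this assay, at which 1 of the 3 values shown sits.

The compounds shown leave open whether a longer chain, such as propyl in place of ethyl, would extend the modest gain. They also cannot separate the hydroxy from the added methyl within 4-hydroxy-2-methylphenyl, nor tell how an amine in place of that hydroxy would read.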